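Swapping the Aryl Group on a Prolinol-Bearing Core

A few compounds are considered here, and "the series" means these few. Any claim that something is new, unique, unknown or untested is made for them only; others in the source may bear on it.

Of the compounds shown here, two have been measured in an assay on CHO cells for displacement of a labelled ligand from adenosine receptor A1 (Homo sapiens), read by scintillation counting, with a stated time of 3 h; on this read-out higher numbers stand for weaker inhibition and lower numbers for stronger inhibition. Compound 1 `Clc1ncnc2sc(Nc3cccc(Br)c3)nc12` carries a chlorine on the shared core and a 3-bromophenyl amine; in this assay compound 1 gives 12600 nM. Compound 2 `OC[C@@H]1CCCN1c1ncnc2sc(Nc3ccc(Cl)cc3)nc12` instead bears a hydroxymethyl-pyrrolidine on the core together with a 4-chlorophenyl amine, and in this assay compound 2 gives 629 nM, the lowest of the two numbers and well beyond the scatter from compound 1.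

Compound 3 `OC[C@@H]1CCCN1c1ncnc2sc(Nc3cccc(Br)c3)nc12` keeps the prolinol-bearing core of compound 2 and changes only the aryl amine: 3-bromophenyl in place of 4-chlorophenyl on a nitrogen on an aromatic ring. For the measured compounds named here, the same bromophenyl amine is present in compound 1, but compound 1 also differs at the core, so no direct step for this change exists among the measured compounds.

With no measured guide for the aryl swap alone, the expected step of a 1.1-fold higher number from compound 2 to compound 3 (0.05 log units; within the scatter) is small, in either direction, and likely within the scatter. Compound 3 is therefore estimated at 700 nM, with a range from 150 nM to 3000 nM.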

Compound 3, inhibition constant: 530 nM
Compound 3: the middle estimate sits 1.3-fold (0.12 log units) above what was measured; low and high end bracket the measured number.
By their numbers in this assay, from the lowest: compounds 3 and 2 (each within the scatter of the next); then compound 1.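

In this assay, the step with 3-bromophenyl in place of 4-chlorophenyl on a nitrogen on an aromatic ring is a 1.2-fold lower number from compound 2 to compound 3 (0.07 log units; within the scatter), so these two aryl groups, which differ in both the halogen and its place on the ring, cannot be told apart on this read-out. For the compounds shown here, compound 3 also gives the first comparison in which only the group on the aromatic carbon of the shared core differs: 2-(hydroxymethyl)pyrrolidin-1-yl in place of chloro gives a 24-fold lower number from compound 1 to compound 3 (1.38 log units; beyond the scatter), a large step that the earlier pair could not show, since compound 1 and compound 2 differ in two places. No measurement is at hand that explains either step.

As far as these compounds go, it remains open whether the large step needs the whole 2-(hydroxymethyl)pyrrolidin-1-yl group, which a plain pyrrolidine or a small amine such as dimethylamino on the same carbon could help to answer. From the compounds shown here alone, it is equally open whether the aryl amine tolerates groups further from these two, such as an unsubstituted phenyl, a methoxyphenyl or a pyridine ring.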